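From butyl to isobutyl: compound 2 and compound 4

The source may hold more compounds than are shown below. What is called first, only, known or untested is meant among the compounds shown, and "the series" means these compounds.

In a physicochemical assay for acid dissociation, compound 2 `CCCCOc1noc2c1CNCC2` gives 7.6. Compound 1 `C#CCOc1noc2c1CNCC2` gives 7.6, so the two stand level, together at the top of the three numbers available. Compound 3 `COc1noc2c1CN(Cc1ccccc1)CC2` gives 6, which stands well apart from both.

The next structure is compound 4 `CC(C)COc1noc2c1CNCC2`, which rearranges the chain of compound 2: isopropyl in place of propyl on a saturated chain carbon bound to an oxygen on an aromatic ring. In words, this is isopropyl in place of propyl on a saturated chain carbon bound to an oxygen on an aromatic ring, or, cut one bond further out, butyl to isobutyl.

Going by the values given here, one measured step bears on this change. At the same place, propyl in place of ethynyl gives no change at the digits printed from compound 1 to compound 2 (within the scatter). Among the compounds with values here, compound 3 supplies no step that differs in this place alone, and no isobutyl chain has yet been measured, so the evidence is thin. Even so, the one change measured at this place left the number unmoved, and the change here keeps the same atoms.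

In this assay, the expected outcome is no change at the digits printed from compound 2 to compound 4 (within the scatter), with no shift beyond the scatter in either direction. For compound 4 the estimated value is 7.6, within an expected range of 7.3 to 7.9.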

Compound 4, acid dissociation constant: 7.7
Estimate against measurement, compound 4: 0.10 log units below; the measured number falls inside the stated range.
By their numbers in this assay, from the lowest: compound 3; then compounds 1, 2 and 4 (each within the scatter of the next).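

In this assay, rearranging the chain on a saturated chain carbon bound to an oxygen on an aromatic ring gives a number 0.10 log units higher from compound 2 to compound 4 (within the scatter), so a change that keeps the same atoms but joins them differently stays within the scatter, as the earlier step from ethynyl to propyl did. Going by these compounds alone, replacing ethynyl directly with isopropyl gives a number 0.10 log units higher from compound 1 to compound 4 (within the scatter), which means that compounds 1, 2 and 4 now form a set of three different groups at this place with no step among them beyond the scatter, a reading that rested on a single step before. No measurement shown here offers an explanation for this flat set of readings.

On these data alone, whether the number stays as flat with an amine, a carboxylic acid or a much longer chain at this place remains open, as all three compounds compared here carry short carbon chains on that oxygen. Compound 3, at 6, differs from the others in more than one place, so the compounds shown cannot assign its gap to any single change.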